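The compounds below may be only part of what the source reports. "The series", "measured", "known", "first", "only" and "open" are said of these compounds alone.

Measured compounds:
compound 1 `O=C(/C=C/c1ccc(Cl)cc1)c1ccc(OCCCSC(=S)N2CCCC2)cc1` gives 34500 nM in a functional assay on MGC-803 cells (Homo sapiens) for inhibition, read by MTT assay, with a stated time of 72 h; a lower number here means a stronger inhibitor, a higher number a weaker inhibitor
compound 2 `CN1CCN(C(=S)SCCCOc2ccc(C(=O)/C=C/c3ccc(Cl)cc3)cc2)CC1` gives 29400 nM in this assay

Compound 1 shows the highest of the two numbers in this assay; its nearest neighbour is compound 2, and the step of a 1.2-fold lower number from compound 1 to compound 2 (0.07 log units; within the scatter) keeps the two within the scatter, so no order between them is claimed.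

Compound 3 `O=C(/C=C/c1ccc(Cl)cc1)c1ccc(OCCSC(=S)N2CCCC2)cc1` has not been measured. It differs from compound 1 by a group of 8 heavy atoms (5 carbon, 1 nitrogen, 2 sulfur; one five-membered non-aromatic ring with 1 hetero atom) in place of a group of 9 heavy atoms (6 carbon, 1 nitrogen, 2 sulfur; one five-membered non-aromatic ring with 1 hetero atom), on a saturated chain carbon, two bonds along the chain from an oxygen on an aromatic ring, that is, on a saturated chain carbon, two bonds along the chain from an oxygen on an aromatic ring.

Among the measured compounds shown here, the single measured step, from compound 1 to compound 2, alters the group on the thiocarbonyl carbon and leaves the chain untouched; it does not bear on the change to compound 3. For the measured compounds named here, no measured step informs this change. Compound 3 is therefore expected to sit near compound 1, with a 1.2-fold lower number from compound 1 to compound 3 (0.06 log units; within the scatter) expected to fall within the scatter, and a wide range is carried.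

Compound 3 is estimated at 30000 nM, ranging from 10000 nM to 90000 nM.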

Compound 3, half-maximal inhibitory concentration: 47900 nM
Compound 3: the middle estimate sits 1.6-fold (0.20 log units) below what was measured; low and high end bracket the measured number.
By their numbers in this assay, from the lowest: compounds 2, 1 and 3 (each within the scatter of the next).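

In this assay, among the compounds shown here, the group of 8 heavy atoms (5 carbon, 1 nitrogen, 2 sulfur) in place of the group of 9 heavy atoms (6 carbon, 1 nitrogen, 2 sulfur) gives a 1.4-fold higher number from compound 1 to compound 3 (0.14 log units; within the scatter) and provides the first reading at this position, on a saturated chain carbon, two bonds along the chain from an oxygen on an aromatic ring. This change therefore leaves the number within the scatter, and no order between these two compounds is claimed. No measurement on hand offers an explanation for this result.

Going by these compounds, whether a longer chain at this position would stay within the scatter remains open. Also open is whether a morpholine ring on the thiocarbonyl carbon would separate from the compounds shown.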